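Amino in place of dimethylamino: what to expect

A few compounds are considered here, and "the series" means these few. Any claim that something is new, unique, unknown or untested is made for them only; others in the source may bear on it.

Measured so far in a functional assay on aorta (Rattus norvegicus, strain Sprague-Dawley); a lower number here means that less compound is needed, a higher number that more compound is needed for the effect:
Compound 1 `Cc1nn(-c2ccccc2)c2nc(OCc3ccccc3F)c(-c3nc(N)c(N4CCCCC4)c(N)n3)cc12` gives 790 nM
Compound 2 `Cc1nn(-c2ccccc2)c2nc(OCc3ccccc3F)c(-c3nc(N)c(N(C)C)c(N)n3)cc12` gives 1100 nM

Among the measured compounds shown here, only two compounds have numbers so far, and they lie within the usual scatter of each other, so compound 2 cannot be ranked against compound 1. Compound 3 `Cc1nn(-c2ccccc2)c2nc(OCc3ccccc3F)c(-c3nc(N)c(N)c(N)n3)cc12` differs from compound 2 by a single change amino in place of dimethylamino on an aromatic carbon with amino in place of dimethylamino on an aromatic carbon. For the measured compounds named here, only one measured step involves this same carbon, with dimethylamino in place of piperidin-1-yl (a 1.4-fold higher number from compound 1 to compound 2 (0.14 log units; within the scatter)). Going by the values given here, it offers only a hint, as no compound with amino at this place has been measured yet. Going by the small size of that step (a 1.4-fold higher number from compound 1 to compound 2 (0.14 log units; within the scatter)), the change expected in this assay is none beyond the scatter (a 1.1-fold higher number from compound 2 to compound 3 (0.04 log units; within the scatter)), and no firm direction can be expected. The estimate for compound 3 is 1200 nM (expected range 350 nM to 4000 nM), a wide span for a group not yet tested here.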

Compound 3, half-maximal effective concentration: 960 nM
The estimate for compound 3 lay 1.3-fold (0.10 log units) above the measured number; measured number inside the range.
By their numbers in this assay, from the lowest: compounds 1, 3 and 2 (each within the scatter of the next).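

With compound 3, this carbon now carries a group with no carbon atoms at all, and this assay still cannot separate it from either earlier compound (a 1.1-fold lower number from compound 2 to compound 3 (0.06 log units; within the scatter); a 1.2-fold higher number from compound 1 to compound 3 (0.08 log units; within the scatter)). Before this result, the only comparison at this carbon was between two groups that both leave the attached nitrogen without a hydrogen, so the amino group is the first here to bring a hydrogen-bond donor. Across piperidin-1-yl, dimethylamino and amino, which differ in heavy atom count, in having a ring and in that donor, the three numbers cannot be ranked, and no available evidence bears on why they lie so close together.

As far as these compounds go, what stays open is whether anything at this carbon can move the number beyond the scatter, for example a carboxylic acid, a methoxy group or a plain hydrogen in place of the nitrogen-linked groups seen so far. From the compounds shown here alone, it is also open whether this insensitivity holds if the two amino groups ortho to this carbon are replaced, as all three compounds carry both of them.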